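The compounds below may be only part of what the source reports. "The series", "measured", "known", "first", "only" and "open" are said of these compounds alone.

Measured compounds:
- compound 1, `CCCCCCCC/C=C\CCCCCCCC(=O)OC[C@@H](C)OP(=O)(O)OC[C@H](N)C(=O)O`: 12.8%
- compound 2, `CCCCCCCC/C=C\CCCCCCCC(=O)OC[C@@H](COCC)OP(=O)(O)OC[C@H](N)C(=O)O`: 12.3%
- compound 3, `C#CCOC[C@H](COC(=O)CCCCCCC/C=C\CCCCCCCC)OP(=O)(O)OC[C@H](N)C(=O)O`: 12.6%

All three numbers come from an assay on HEK293 cells for agonist activity at probable G-protein coupled receptor 34 (Mus musculus), with a stated time of 1 h; on this read-out lower numbers stand for smaller maximal responses and higher numbers for larger maximal responses. The steps of a number 0.5 percentage points lower from compound 1 to compound 2 (within the scatter) and a number 0.2 percentage points lower from compound 1 to compound 3 (within the scatter) both lie within the scatter, as does a number 0.3 percentage points higher from compound 2 to compound 3 (within the scatter). Compound 3 therefore stands on the same level as the other two members; nothing in these numbers separates it from compound 1 or compound 2.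

Compound 4, `CCCCCCCC/C=C\CCCCCCCC(=O)OC[C@@H](COCc1ccccc1)OP(=O)(O)OC[C@H](N)C(=O)O`, is not yet measured. Its difference from compound 3 is phenyl in place of ethynyl on a saturated chain carbon bound to an oxygen on a saturated carbon. Within the data shown here, the same position has so far carried hydrogen, ethoxy and propargyloxy, and the only direct comparison at the carbon bound to the oxygen on a saturated carbon is ethynyl against methyl, which gave a number 0.3 percentage points higher from compound 2 to compound 3 (within the scatter), within the scatter. A phenyl at this place is new to the series, so the expectation rests only on the flatness of the three measured numbers in this assay. On that basis compound 4 is expected to show no step beyond the scatter, with an estimated step of a number 0.4 percentage points higher from compound 3 to compound 4 (within the scatter). Among the measured compounds shown here, for compound 4 the estimated value in this assay is 13%, with a range from 5% to 24%, the range widened because the benzyloxy group has no precedent among the measured compounds.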

Compound 4, largest response reached (Emax), in percent of the reference or control that the assay uses: 9.6%
Estimate against measurement, compound 4: 3.4 percentage points above, within the range that was stated.
By their numbers in this assay, from the lowest: compounds 4, 2, 3 and 1 (each within the scatter of the next).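

In this assay, benzyloxy brings the first aromatic ring to this place, and all three comparisons stay within the scatter: phenyl for ethynyl (a number 3 percentage points lower from compound 3 to compound 4 (within the scatter)), phenyl for methyl (a number 2.7 percentage points lower from compound 2 to compound 4 (within the scatter)) and benzyloxy for hydrogen (a number 3.2 percentage points lower from compound 1 to compound 4 (within the scatter)). The change from ethynyl, with 2 heavy atoms and no ring, to phenyl, with 6 heavy atoms and one six-membered aromatic ring of carbon only, therefore produces no separation on this read-out, and hydrogen, ethoxy, propargyloxy and benzyloxy all remain on one level at this place. No supporting measurement bears on why the series stays this flat.

Still open is whether an amine or a carboxylic acid in place of phenyl on this saturated chain carbon would give a step beyond the scatter in this assay, since every group shown here carries 0 hydrogen-bond donors and no net charge. Also open, on these data alone, is whether a longer chain in place of ethyl, propargyl or benzyl would leave the maximal response on the same level.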